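Working notes: fluoro on the benzyl of compound 3

The source may hold more compounds than are shown below. What is called first, only, known or untested is meant among the compounds shown, and "the series" means these compounds.

Values so far in a functional assay on A549 cells (Homo sapiens) for antiproliferative activity, read by MTT assay, with a stated time of 48 h (a lower number here means a stronger inhibitor, a higher number a weaker inhibitor), for the series
compound 1 `O=[N+]([O-])c1cc(C(F)(F)F)cc([N+](=O)[O-])c1Oc1ccc(Br)cc1/C=N\OCc1ccccc1` gives 2240 nM
compound 2 `O=[N+]([O-])c1cc(C(F)(F)F)cc([N+](=O)[O-])c1Oc1ccc(Br)cc1/C=N\OCc1ccccc1F` gives 1280 nM
compound 3 `O=[N+]([O-])c1cc(C(F)(F)F)cc([N+](=O)[O-])c1Oc1c(Br)cc(Br)cc1/C=N\OCc1ccccc1` gives 2150 nM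

Compound 3 at 2150 nM sits within the scatter of both compound 1 and compound 2, so the three values do not separate. The unmeasured compound 4 `O=[N+]([O-])c1cc(C(F)(F)F)cc([N+](=O)[O-])c1Oc1c(Br)cc(Br)cc1/C=N\OCc1ccccc1F` is compound 3 with one change fluoro in place of hydrogen on an aromatic carbon in which benzyl goes to 2-fluorobenzyl: fluoro in place of hydrogen on an aromatic carbon. The same change has been measured once, as a 1.8-fold lower number from compound 1 to compound 2 (0.24 log units; within the scatter) and that step lies within the scatter. The other measured step, bromo in place of hydrogen on an aromatic carbon, is a 1.0-fold lower number from compound 1 to compound 3 (0.02 log units; within the scatter) and also lies within the scatter, so the bromo of compound 3 gives no reason to expect a different fluoro step there. A single pair is thin evidence. The step expected in this assay is small, toward a lower number if anything, and not clearly beyond the scatter. The estimated step is a 1.6-fold lower number from compound 3 to compound 4 (0.20 log units; within the scatter) and stays an expectation until measured. For compound 4 the estimated value is 1350 nM (expected range 750 nM to 2400 nM).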

Compound 4, half-maximal inhibitory concentration: 1560 nM
Beside the measured number, compound 4's estimate is 1.2-fold (0.06 log units) below it; measured number inside the range.
By their numbers in this assay, from the lowest: compounds 2, 4, 3 and 1 (each within the scatter of the next).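

The fluoro step, until now a single pair, has a second reading in this assay on the dibromo-bearing core of compound 3, a 1.4-fold lower number from compound 3 to compound 4 (0.14 log units; within the scatter), and the two readings agree: the same change on two cores in this assay, a 1.8-fold lower number (0.24 log units; within the scatter) from compound 1 to compound 2 and a 1.4-fold lower number (0.14 log units; within the scatter) from compound 3 to compound 4, 1.3-fold (0.10 log units) apart, within the scatter of two such steps. The bromo step also gains a second reading with 2-fluorobenzyl in place of benzyl, a 1.2-fold higher number from compound 2 to compound 4 (0.09 log units; within the scatter), and these two readings agree as well: the same change on two cores in this assay, a 1.0-fold lower number (0.02 log units; within the scatter) from compound 1 to compound 3 and a 1.2-fold higher number (0.09 log units; within the scatter) from compound 2 to compound 4, 1.3-fold (0.10 log units) apart, within the scatter of two such steps. Across the four compounds, neither change gives a step beyond the scatter, so each change reads alike whether or not the other is present.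

Open, from the compounds shown here alone, is whether any group at this place on the benzyl can give a step beyond the scatter, for example a methoxy, an amine or a carboxylic acid. Also open, going by these compounds, is whether replacing the benzyl with a longer chain would do so.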